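The source may hold more compounds than are shown below. What is called first, only, known or untested is meant among the compounds shown, and "the series" means these compounds.

Series notes. Compound 2 `CCCc1nc(-c2ccccc2)c(CNCCCN2CCN(c3cccc(C(F)(F)F)c3)CC2)o1` gives 51.6% in an assay on HEK293 cells for inhibition of Voltage-dependent T-type calcium channel subunit alpha-1G (Homo sapiens), read by fluorescence, tested at 10 uM; on this read-out lower numbers stand for less inhibition and higher numbers for more inhibition at the one concentration tested (going by the name of the read-out). Compound 1 `CCCc1nc(-c2ccccc2)c(CNCCN2CCN(c3ccccc3Cl)CC2)o1` gives 60.1% in this assay, and compound 3 `CCCc1nc(-c2ccccc2)c(CNCCN2CCN(c3ccc(F)cc3)CC2)o1` gives 54.1%. Among these three numbers compound 2 stands lowest, yet its gap to compound 3 and its gap to compound 1 both fall within the usual scatter, so the three values cannot be ordered with any confidence.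

The next compound is compound 4 `CCCc1nc(-c2ccccc2)c(CNCCCN2CCN(c3ccccc3Cl)CC2)o1`, which differs from compound 2 in a single place: 2-chlorophenyl in place of 3-(trifluoromethyl)phenyl on an amine nitrogen in a ring. Within the data shown here, only one measured step bears on the group held by this amine nitrogen in a ring, namely a number 6 percentage points lower from compound 1 to compound 3 (within the scatter), where one such exchange on that nitrogen left the inhibition inside the scatter. Among the measured compounds shown here, that step runs through a different pair of groups, and compound 4 otherwise matches compound 2, so the transfer is indirect; no measured pair sets 3-(trifluoromethyl)phenyl directly against 2-chlorophenyl. For the measured compounds named here, with the one relevant step flat, the change a number 5.4 percentage points higher from compound 2 to compound 4 (within the scatter) is expected to stay within the scatter, leaning if at all slightly upward. Compound 4 is accordingly estimated at 57% in this assay, with a range from 42% to 72%.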

Compound 4, a percentage reported as inhibition, at one concentration (the size of the read-out at that concentration, not a potency): 64.7%
For compound 4 the middle estimate is 7.7 percentage points below the measured one; low and high end bracket the measured number.
By their numbers in this assay, from the lowest: compounds 2, 3, 1 and 4 (each within the scatter of the next, the first and the last beyond it).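

Among these compounds, the exchange of 3-(trifluoromethyl)phenyl for 2-chlorophenyl gives a number 13.1 percentage points higher from compound 2 to compound 4 (beyond the scatter) in this assay and is thus the first change on this amine nitrogen in a ring to clear the scatter, while the earlier exchange there gave a number 6 percentage points lower from compound 1 to compound 3 (within the scatter) and settled nothing. The position therefore responds to the choice of aryl group in at least this one pair, although the step is modest and compound 1 at 60.1% and compound 4 at 64.7% both carry 2-chlorophenyl and lie within the scatter of each other despite their different chains. No evidence at hand accounts for the step.

Because this exchange changes both the substituent and where it sits on the phenyl ring, the compounds shown cannot separate the two, and 3-chlorophenyl or 2-(trifluoromethyl)phenyl on the same nitrogen would be needed to do so. Also open, from the compounds shown here alone, is how unsubstituted phenyl or 2-methoxyphenyl would compare there, and whether a step of this kind would hold on the shorter chain of compound 1.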